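The source may report more compounds than this note shows. Statements on the series, on what has been measured and on what is new or still open speak of the compounds shown alone.

Measured so far in a functional assay on A549 cells (Homo sapiens) for inhibition, read by MTT assay, with a stated time of 48 h; on this read-out lower numbers stand for stronger inhibition and higher numbers for weaker inhibition:
compound 1 `COc1cc2cc(NC(C)=O)c(=O)oc2cc1OCCCOc1no[n+]([O-])c1S(=O)(=O)c1ccccc1` gives 9810 nM;
compound 2 `COc1cc2cc(NC(C)=O)c(=O)oc2cc1OCCCCOc1no[n+]([O-])c1S(=O)(=O)c1ccccc1` gives 7190 nM;
compound 3 `COc1cc2cc(N)c(=O)oc2cc1OCCCOc1no[n+]([O-])c1S(=O)(=O)c1ccccc1` gives 4180 nM.

Compound 3 is compound 1 with the change (hydrogen in place of acetyl on a nitrogen on an aromatic ring). That change gave a 2.3-fold lower number from compound 1 to compound 3 (0.37 log units; beyond the scatter).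

Compound 2 differs from compound 1 in the core; the difference between the two cores is not broken down here. The values of compound 2 and compound 1 lie within the scatter of each other, as do those of compound 2 and compound 3.

Compound 4 `COc1cc2cc(N)c(=O)oc2cc1OCCCCOc1no[n+]([O-])c1S(=O)(=O)c1ccccc1` is not yet measured. It is compound 2 with the change (hydrogen in place of acetyl on a nitrogen on an aromatic ring), the same change as from compound 1 to compound 3, at the same kind of place. In this assay, among the compounds with values here, a step of about the same size, a 2.2-fold lower number from compound 2 to compound 4 (0.35 log units; beyond the scatter), is expected for compound 4, because the single prior instance gave a 2.3-fold lower number from compound 1 to compound 3 (0.37 log units; beyond the scatter). The estimate for compound 4 is 3200 nM, expected to fall between 1500 nM and 7000 nM.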

Compound 4, half-maximal inhibitory concentration: 5030 nM
For compound 4 the middle estimate is 1.6-fold (0.20 log units) below the measured one, within the range that was stated.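

The acetamido to amino change on the core of compound 2 gives, in this assay, a 1.4-fold lower number from compound 2 to compound 4 (0.16 log units; within the scatter), so on this core the step does not stand clear of the scatter. Set beside the earlier step, the two do not differ by more than the scatter allows: the same change on two cores in this assay, a 2.3-fold lower number (0.37 log units; beyond the scatter) from compound 1 to compound 3 and a 1.4-fold lower number (0.16 log units; within the scatter) from compound 2 to compound 4, 1.6-fold (0.22 log units) apart, within the scatter of two such steps

The change therefore carries from one core to the other with no detectable difference in size, but two pairs in one cell assay cannot show that the step is fixed, or that it is real on the core of compound 2.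

Open, on these data alone, is whether benzoyl or methyl in place of acetyl on the nitrogen would fit these steps. Also open, as far as these compounds go, is whether the step holds on a longer chain.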